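Chlorine on the thiazole ring and cytotoxicity in KB cells

This account rests on a few compounds, and the source may have more. Where it says the series, first, only, none or still open, it means among the compounds named here.

Measured compounds:
- compound 1, `COc1ccnc(-c2csc(Nc3ccc(Cl)cn3)n2)c1`, 62800 nM
- compound 2, `COc1ccnc(-c2nc(Nc3ccc(Cl)cn3)sc2Cl)c1`, 15000 nM
- compound 3, `Clc1ccc(Nc2nc(-c3cnccn3)cs2)nc1`, "not determined" (no result reported)

These values come from an ADME assay on KB cells (Homo sapiens) for cytotoxicity, read by MTT assay, with a stated time of 72 h; on this read-out higher numbers stand for lower toxicity in this test and lower numbers for higher toxicity in this test. Compound 4, `Clc1ccc(Nc2nc(-c3cnccn3)c(Cl)s2)nc1`, has not yet been measured there. The change from compound 3 to compound 4, (chloro in place of hydrogen on an aromatic carbon), is the same kind of change as from compound 1 to compound 2, (chloro in place of hydrogen on an aromatic carbon), which gave a 4.2-fold lower number from compound 1 to compound 2 (0.62 log units; beyond the scatter). The places differ only in what the neighbouring ring atom bears: a pyrazin-2-yl group (6 heavy atoms) in compound 3, a group of 8 heavy atoms in compound 1. Within the data shown here, how the core of compound 3 differs from the core of compound 1 is not broken down here, and compound 3 has no number, so no step can be computed for compound 4. An estimate for compound 4 in this assay must therefore rest on the values of compound 1 and compound 2 alone, and is expected to be 20000 nM, between 5000 nM and 80000 nM.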

Compound 4, half-maximal cytotoxic concentration in the KB assay: 3170 nM
For compound 4 the middle estimate is 6.3-fold (0.80 log units) above the measured one; the whole stated range lies above it.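

In a physicochemical assay for solubility, in phosphate buffer, with a stated time of 2 h, at pH 7.4 (a higher number here means a more soluble compound, a lower number a less soluble compound), compound 3 gives < 10000 nM as a limit of the assay, not a number. In the physicochemical assay compound 4 also gives a limit, < 10000 nM and not a number.

No step from compound 3 to compound 4 can be read, because both values are the same limit: the limit of < 10000 nM in the physicochemical assay, at which 2 of the 2 values shown sit.

On these data alone, how far chloro in place of hydrogen changes the solubility of compound 3 stays open.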